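The compounds below may be only part of what the source reports. "The series", "measured", "known", "first", "only" and "open" are said of these compounds alone.

Two compounds of the series have been run in an ADME assay on Vero cells (Chlorocebus sabaeus) for cytotoxicity, read by MTT assay, with a stated time of 48 h; on this read-out lower numbers stand for stronger inhibition and higher numbers for weaker inhibition. Compound 1 `C(=C1\CCCC\C1=N/Nc1nc(-c2ccccc2)cs1)\c1ccccc1` gives in this assay a value that is a limit of the assay, > 100000 nM. Compound 2 `COc1ccc(-c2csc(N/N=C(\C)CCO)n2)cc1` likewise gives only a limit in this assay, > 100000 nM. Both readings therefore fall at the limit of > 100000 nM in this assay, at which 2 of the 2 values shown sit, so compound 1 stands on the shared limit rather than at a number of its own, and no order between compound 1 and compound 2 can be drawn.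

Compound 3 `COc1ccc(-c2csc(N/N=C3\CCCC\C3=C/c3ccccc3)n2)cc1` has not yet been measured in this assay. It differs from compound 1 by methoxy in place of hydrogen on an aromatic carbon. Among the measured compounds shown here, no step between two measured compounds is available, so the expectation rests on the two limits alone. The step of a number no higher from compound 1 to compound 3 (the limit leaves the size open) is expected to lie within the scatter, with no direction favoured. For compound 3 the estimate in this assay is 100000 nM, between 50000 nM and 300000 nM, and a further limit is the likelier report.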

Compound 3, half-maximal inhibitory concentration: > 100000 nM
Compound 3 ended at the assay's limit (the forecaster's own chance of this, stated with the estimate: 85%); the middle value lies on the limit itself.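

Compound 1 and compound 3 both sit at a limit in this assay, so no step can be read between them: the limit of > 100000 nM in this assay, at which 3 of the 3 values shown sit.

The compounds shown leave open whether phenyl to 4-methoxyphenyl changes the read-out at all, and whether any compound of the series reaches a number of its own in this assay.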